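Aryl swap at the core: outlook for compound 4

The source may hold more compounds than are shown below. What is called first, only, known or untested is meant among the compounds shown, and "the series" means these compounds.

Compound 1 `COc1ccc(C(=O)/C=C/c2cc(-c3cc(OC)c(OC)c(OC)c3)n3nc(-c4ccccc4)cc3n2)cc1` — 13200 nM
Compound 2 `COc1cc(-c2cc(C(=O)/C=C/c3ccccc3)nc3cc(-c4ccccc4)nn23)cc(OC)c1OC` — 19200 nM
Compound 3 `COc1cc(-c2cc(/C=C/C(=O)c3ccc(C)cc3)nc3cc(-c4ccccc4)nn23)cc(OC)c1OC` — 23900 nM

In a functional assay on MDA-MB-231 cells (Homo sapiens) for antiproliferative activity, read by MTT assay, with a stated time of 24 h (on this read-out higher numbers stand for weaker inhibition and lower numbers for stronger inhibition), compound 1 gives 13200 nM, the lowest of the three numbers, though its separation from the others is small: a 1.5-fold higher number from compound 1 to compound 2 (0.16 log units; within the scatter) and a 1.8-fold higher number from compound 1 to compound 3 (0.26 log units; within the scatter) are both within the scatter, as is a 1.2-fold higher number from compound 2 to compound 3 (0.10 log units; within the scatter). All three measured steps concern the enone end of the molecule and leave the aryl group on the shared core untouched.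

Compound 4 `COc1ccc(C(=O)/C=C/c2cc(-c3ccc(OC)cc3)n3nc(-c4ccccc4)cc3n2)cc1` changes exactly that untouched part: 4-methoxyphenyl in place of 3,4,5-trimethoxyphenyl on an aromatic carbon. Within the data shown here, no measured step bears on this position, so the series gives no direct guide to its size or direction. With the enone-side changes all falling within the scatter, the working expectation is a number near compound 1 or somewhat higher, with wide uncertainty. Compound 4 is estimated at 22000 nM in this assay, a range of 8000 nM to 60000 nM, corresponding to an expected 1.7-fold higher number from compound 1 to compound 4 (0.22 log units; within the scatter).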

Compound 4, half-maximal inhibitory concentration: 6300 nM
Compound 4: middle estimate off by 3.5-fold (0.54 log units), on the high side; measured number below the stated range.
By their numbers in this assay, from the lowest: compound 4; then compounds 1, 2 and 3 (each within the scatter of the next).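

In this assay, among these compounds, the aryl group on the shared core is the first place where a single change moves the number beyond the scatter: a 2.1-fold lower number from compound 1 to compound 4 (0.32 log units; beyond the scatter), with 4-methoxyphenyl in place of 3,4,5-trimethoxyphenyl. The enone-end steps among compound 1, compound 2 and compound 3 all stayed within the scatter, so this position is the only one shown so far with a readable effect, and the full 3,4,5-trimethoxyphenyl group is not needed for the lower number. Nothing on hand explains the step.

Which of the lost methoxy groups matters cannot be told from this single change. Also open, from the compounds shown here alone, are how an unsubstituted phenyl or a 4-hydroxyphenyl would read at this position, and whether the step carries over to the enone ends of compound 2 and compound 3.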